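Methyl Steps on Two Pyridine-Urea Cores at Receptor 2

This account rests on a few compounds, and the source may have more. Where it says the series, first, only, none or still open, it means among the compounds named here.

Compound 1, `CCOc1cc(NC(=O)NCc2cc(C)c(-c3cn(C)nc3C(F)(F)F)nn2)cc(C#N)n1`: in a functional assay on HFL1 cells for antagonist activity at sphingosine 1-phosphate receptor 2 (Homo sapiens), read by ELISA, with a stated time of 24 h, in the presence of a further agent that is not named here (on this read-out higher numbers stand for weaker inhibition and lower numbers for stronger inhibition), compound 1 gives 67000 nM
Compound 2, `Cc1cc(CNC(=O)Nc2cc(OCCO)nc(C(F)(F)F)c2)nnc1-c1cn(C)nc1C(F)(F)F`: compound 2 gives 810000 nM
Compound 3, `CCOc1nc(C#N)cc(NC(=O)NCc2cc(C)c(-c3cn(C)nc3C(F)(F)F)nn2)c1C`: compound 3 gives 17000 nM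

Compound 3 differs from compound 1 by a single change, (methyl in place of hydrogen on an aromatic carbon), and that change gave a 3.9-fold lower number from compound 1 to compound 3 (0.60 log units; beyond the scatter). Compound 2 stands apart from both: the difference between its core and the core of compound 1 is not broken down here, and its number is the highest of the three.

Compound 4, `Cc1cc(CNC(=O)Nc2cc(C(F)(F)F)nc(OCCO)c2C)nnc1-c1cn(C)nc1C(F)(F)F`, has not yet been measured. It differs from compound 2 by methyl in place of hydrogen on an aromatic carbon. Within the data shown here, this is the same kind of change as the one from compound 1 to compound 3, though the surroundings differ: in compound 4 the methyl enters ortho to a 2-hydroxyethoxy group and para to a trifluoromethyl group, whereas in compound 3 it enters ortho to an ethoxy group and para to a cyano group. Because the earlier step was a 3.9-fold lower number from compound 1 to compound 3 (0.60 log units; beyond the scatter), a modest lowering of similar size is expected here as well, a 3.2-fold lower number from compound 2 to compound 4 (0.51 log units; beyond the scatter). The differing surroundings leave that expectation less firm. Compound 4 is therefore estimated at 250000 nM in this assay, with a likely range from 80000 nM to 900000 nM.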

Compound 4, half-maximal inhibitory concentration: 256000 nM
Estimate against measurement, compound 4: 1.0-fold (0.01 log units) below; the measured number falls inside the stated range.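

In this assay, placing a methyl on the aromatic carbon in place of hydrogen gave a 3.2-fold lower number from compound 2 to compound 4 (0.50 log units; beyond the scatter), and this step matches the earlier one in size: the same change on two cores in this assay, a 3.9-fold lower number (0.60 log units; beyond the scatter) from compound 1 to compound 3 and a 3.2-fold lower number (0.50 log units; beyond the scatter) from compound 2 to compound 4, 1.2-fold (0.10 log units) apart, within the scatter of two such steps So on these two cores the change carried over with much the same size, even though its surroundings differ: in compound 4 the methyl sits ortho to a 2-hydroxyethoxy group and para to a trifluoromethyl group, while in compound 3 it has an ethoxy group and a cyano group in those places. Two pairs of compounds do not make a general rule for this series, however, and they do not show why the methyl lowers the number.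

The compounds shown leave open whether an ethyl group, a chlorine atom or an amine on the same carbon would lower the number as the methyl does. They also leave open whether the methyl step would keep its size on a core carrying a carboxylic acid in place of the cyano or trifluoromethyl group.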